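Swapping the aryl group on a shared core: lipophilicity

A few compounds are considered here, and "the series" means these few. Any claim that something is new, unique, unknown or untested is made for them only; others in the source may bear on it.

Compound 1 `Cc1cccc(-c2cn3ccnc3c(-c3ccc4ncn(C5CCCCC5)c4c3)n2)c1` gives 1.87 in a physicochemical assay for lipophilicity, using the shake flask method, in phosphate buffer, measured as octanol-water partition, with a stated time of 85 min, at pH 7.4; on this read-out lower numbers stand for lower lipophilicity and higher numbers for higher lipophilicity.
Compound 2 `CCc1ccc(-c2cn3ccnc3c(-c3ccc4ncn(C5CCCCC5)c4c3)n2)cc1` gives 1.66 in this assay.
Compound 3 `CCc1ccc(-c2cn3ccnc3c(-c3ccc4ncn(Cc5ccccc5)c4c3)n2)cc1` gives 1.96 in this assay.

Compound 3 shows the largest of the three numbers, but the gap to compound 1 and the gap to compound 2 both lie within the usual scatter, so the three compounds cannot be separated on this measurement. The change now considered is 3-methylphenyl in place of 4-ethylphenyl on an aromatic carbon, giving compound 4 `Cc1cccc(-c2cn3ccnc3c(-c3ccc4ncn(Cc5ccccc5)c4c3)n2)c1`. Within the data shown here, one measured step bears directly on it: a number 0.21 log units lower from compound 1 to compound 2 (within the scatter), which is the same exchange run in the opposite direction and was within the scatter. The other measured step, a number 0.30 log units higher from compound 2 to compound 3 (within the scatter), concerns the group on the aromatic nitrogen and therefore does not touch this change; it only confirms that the benzyl-bearing core of compound 3 sits close to the cyclohexyl-bearing core of compound 2. Reversing the step seen from compound 1 to compound 2 suggests that compound 4 will come out slightly above compound 3, by an amount no larger than the scatter. The expected step is a number 0.19 log units higher from compound 3 to compound 4 (within the scatter). Compound 4 is estimated at 2.15, with a range from 1.8 to 2.5.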

Compound 4, partition coefficient: 2.16
Estimate against measurement, compound 4: 0.01 log units below; low and high end bracket the measured number.
By their numbers in this assay, from the lowest: compounds 2, 1, 3 and 4 (each within the scatter of the next, the first and the last beyond it).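

In this assay, the exchange of 4-ethylphenyl for 3-methylphenyl on this aromatic carbon can now be read with benzyl on the aromatic nitrogen as well as with cyclohexyl: there is a number 0.20 log units higher from compound 3 to compound 4 (within the scatter), set against a number 0.21 log units lower from compound 1 to compound 2 (within the scatter) for the same exchange run the other way. The change on the nitrogen can also now be read with both aryl groups, as a number 0.29 log units higher from compound 1 to compound 4 (within the scatter) with 3-methylphenyl beside a number 0.30 log units higher from compound 2 to compound 3 (within the scatter) with 4-ethylphenyl, so within these four compounds each exchange gives a step of nearly the same size whichever group sits at the other place, although every one of these steps is within the scatter. Nothing measured here explains these small steps or their similar size.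

The exchange alters the length of the chain and its place on the phenyl ring together, so these compounds leave open how 4-methylphenyl or 3-ethylphenyl would compare. As far as these compounds go, how far an amine or a carboxylic acid on that phenyl ring would move the number also remains open.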